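The compounds below may be only part of what the source reports. "The series", "measured", "known", "first", "only" and "open" are said of these compounds alone.

Measured so far:
compound 1 `COc1ccc(NCc2nc3ccccc3[nH]2)cc1` — 29.4%
compound 2 `Cc1ccc(NCc2nc3ccc(Br)cc3[nH]2)cc1` — 23.5%

Compound 2 carries the smaller of the two figures, but the gap to compound 1 lies within the scatter, so the two are not separated. Compound 3 `COc1ccc(NCc2nc3ccc(Br)cc3[nH]2)cc1` differs from compound 2 in one change: methoxy in place of methyl on an aromatic carbon. Within the data shown here, no step between measured compounds bears on this change, so its size in a functional assay on the whole organism (strain albino) for inhibition, with Rattus norvegicus as the target, read by paw edema, with a stated time of 120 min, at a dose of 100 mg/kg by the oral route (a higher number here means more inhibition at the dose given (going by the name of the read-out), a lower number less inhibition), is unknown; none beyond the scatter is expected, because compound 1, which also carries methoxy, gives 29.4% while compound 2 gives 23.5%. The expected step is a number 3.5 percentage points higher from compound 2 to compound 3 (within the scatter). Compound 3 is estimated at 27%, between 15% and 40%.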

Compound 3, a percentage reported as inhibition, in the whole organism at one dose (the size of the read-out at that dose, not a potency): 17.6%
Compound 3: middle estimate off by 9.4 percentage points, on the high side; measured number inside the range.
By their numbers in this assay, from the lowest: compounds 3, 2 and 1 (each within the scatter of the next, the first and the last beyond it).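

In this assay methoxy in place of methyl on an aromatic carbon para to a large group gives a number 5.9 percentage points lower from compound 2 to compound 3 (within the scatter) and so is not separated from no change at this position. Among these compounds, with methoxy held, bromo in place of hydrogen on an aromatic carbon gives a number 11.8 percentage points lower from compound 1 to compound 3 (beyond the scatter) as the only step so far beyond the scatter. Nothing measured here accounts for either step.

Open, from the compounds shown here alone, is whether the bromo step also holds with methyl in place of methoxy. Also open, going by these compounds, is how an amine, a carboxylic acid or a chloro would read at these two places.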